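Replacing a pyridinyl arm with a methoxypyridinyloxy arm

The compounds below may be only part of what the source reports. "The series", "measured", "known", "first", "only" and "open" are said of these compounds alone.

Measured so far:
compound 1 `O=C1C(=O)N(Cc2ccc(-c3cccnc3)cc2)c2ccc(OC(F)(F)F)cc21` — 51%
compound 2 `O=C1C(=O)N(Cc2ccc(Cl)nc2)c2ccc(OC(F)(F)F)cc21` — 80%

Of the compounds shown here, two share a core and have been tested in a functional assay on CHO cells for positive allosteric modulation of muscarinic acetylcholine receptor M5 (Homo sapiens), read by FLIPR and calcium flux, with a stated time of 1 h; on this read-out lower numbers stand for smaller maximal responses and higher numbers for larger maximal responses. Compound 1 gives 51%, the lower of the two numbers; compound 2 gives 80%, a gap that lies beyond the usual scatter of the measurement. Among the compounds with values here, no pair that differs in only one place has been measured, so no step size can be read from the data themselves.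

Compound 3 `COc1cccc(Oc2ccc(CN3C(=O)C(=O)c4cc(OC(F)(F)F)ccc43)cc2)n1` has not yet been measured. It differs from compound 1 in one place: (6-methoxypyridin-2-yl)oxy in place of pyridin-3-yl on an aromatic carbon. The entering group is larger and carries more hydrogen-bond acceptors than the group it replaces.

Within the data shown here, with no measured step to lean on, the expectation for compound 3 is a modest rise in maximal response, a number 11 percentage points higher from compound 1 to compound 3 (beyond the scatter), but the uncertainty is wide. Compound 3 is estimated to reach 62%, expected to fall between 38% and 88%.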

Compound 3, largest response reached (Emax), in percent of the reference or control that the assay uses: 51%
Beside the measured number, compound 3's estimate is 11 percentage points above it; low and high end bracket the measured number.
By their numbers in this assay, from the lowest: compounds 1 and 3 (each within the scatter of the next); then compound 2.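

Within the data shown here, this is the first step measured at this position: in this assay, placing (6-methoxypyridin-2-yl)oxy in place of pyridin-3-yl on the aromatic carbon gives no change at the digits printed from compound 1 to compound 3 (within the scatter) and nothing more. The entering group is larger and carries more hydrogen-bond acceptors, yet the maximal response of the two compounds cannot be told apart, so for this pair, neither difference shows up in the read-out. Nothing measured here explains this outcome.

A single step cannot show whether the methoxy group or the oxygen link contributes anything on its own, since the two enter together. As far as these compounds go, it also remains open whether a primary amine or a carboxylic acid on the same aromatic carbon would move the maximal response away from that of compound 1.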